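Nitro in place of trifluoromethyl: compound 1 to compound 3

This account rests on a few compounds, and the source may have more. Where it says the series, first, only, none or still open, it means among the compounds named here.

Of the compounds shown here, two built on a shared core have been measured so far. In an ADME assay on Vero cells (Chlorocebus sabaeus) for cytotoxicity, read by flow cytometry and propidium iodide staining, with a stated time of 72 h (a higher number here means a weaker inhibitor, a lower number a stronger inhibitor), compound 1 (`O=S(=O)(c1ccc(C(F)(F)F)cc1)n1cnc2ccccc21`) gives 460000 nM, the higher of the two numbers. Compound 2 (`O=S(=O)(c1cccc(C(F)(F)F)c1)n1cnc2ccccc21`) gives 59800 nM, and the gap between the two lies beyond the usual scatter of repeated measurements. Compound 1 therefore sits at the weak end of this small set.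

The next compound to be tested is compound 3 (`O=[N+]([O-])c1ccc(S(=O)(=O)n2cnc3ccccc32)cc1`). It carries nitro in place of trifluoromethyl on an aromatic carbon, para to a large group, and the rest of the structure is unchanged: nitro in place of trifluoromethyl on an aromatic carbon.

Within the data shown here, no measured pair shows what this exchange does, so the size of the step in this assay remains a judgement. A moderate move towards a lower number is expected, probably beyond the scatter, since compound 2 at 59800 nM shows that much lower numbers occur on this core. The expected change is a 4.6-fold lower number from compound 1 to compound 3 (0.66 log units; beyond the scatter). Compound 3 is estimated at 100000 nM, with an expected range of 25000 nM to 400000 nM.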

Compound 3, half-maximal inhibitory concentration: 347000 nM
The estimate for compound 3 lay 3.5-fold (0.54 log units) below the measured number, and the stated range covers the measured number.
By their numbers in this assay, from the lowest: compound 2; then compounds 3 and 1 (each within the scatter of the next).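

In this assay, among these compounds, nitro in place of trifluoromethyl on an aromatic carbon, para to a large group, gives a 1.3-fold lower number from compound 1 to compound 3 (0.12 log units; within the scatter), and this is the only step that can be read on the shared core so far. At this position the two groups therefore cannot be told apart by their numbers, even though the entering nitro counts 2 hydrogen-bond acceptors and the leaving trifluoromethyl counts 0. No measurement accompanies these numbers that could account for this result.

The compounds shown leave open whether an amine or a carboxylic acid on the same aromatic carbon would also stay within the scatter of compound 1. They also leave open whether nitro would match trifluoromethyl on the ring carbon that carries trifluoromethyl in compound 2, which gives 59800 nM.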